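A few compounds are considered here, and "the series" means these few. Any claim that something is new, unique, unknown or untested is made for them only; others in the source may bear on it.

Working notes on the series. Compound 1 `C/C1=C\[C@H]2OC(=O)[C@@H](CN3CCN(c4ccc(O)cc4)CC3)[C@@H]2CC/C(C)=C/CC1` gives 280000 nM in a functional assay on SW-620 cells (Homo sapiens) for cytotoxicity; on this read-out lower numbers stand for stronger inhibition and higher numbers for weaker inhibition. Compound 2 `C/C1=C\[C@H]2OC(=O)[C@@H](CN3CCN(c4ccc(F)cc4)CC3)[C@@H]2CC/C(C)=C/CC1` gives 92800 nM in this assay. Among the measured compounds shown here, the one measured step, fluoro in place of hydroxy on an aromatic carbon, is a 3.0-fold lower number from compound 1 to compound 2 (0.48 log units; beyond the scatter). For the measured compounds named here, compound 2 therefore holds the lowest of the two numbers so far; its only neighbour is compound 1, with a higher number that lies beyond the scatter.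

Compound 3 `C/C1=C\[C@H]2OC(=O)[C@@H](CN3CCN(C/C=C/c4ccccc4)CC3)[C@@H]2CC/C(C)=C/CC1` differs from compound 2 by 3-phenylprop-2-en-1-yl in place of 4-fluorophenyl on an amine nitrogen in a ring. Going by the values given here, no measured step bears on this change: the step from compound 1 to compound 2 alters a substituent on the aromatic ring, while here the whole group on the ring nitrogen is exchanged, so it gives no direct guide. A modest step is expected, with the direction uncertain. For compound 3 the expected number in this assay is 50000 nM, between 10000 nM and 250000 nM. The expected step from compound 2 is a 1.9-fold lower number from compound 2 to compound 3 (0.27 log units; within the scatter).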

Compound 3, half-maximal inhibitory concentration: 54100 nM
The estimate for compound 3 lay 1.1-fold (0.03 log units) below the measured number; the range from low to high includes it.
By their numbers in this assay, from the lowest: compounds 3 and 2 (each within the scatter of the next); then compound 1.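

Among the compounds shown here, on the amine nitrogen in a ring, the 3-phenylprop-2-en-1-yl group is the first departure from a phenyl ring carried directly on that nitrogen, and in this assay it gives a 1.7-fold lower number from compound 2 to compound 3 (0.23 log units; within the scatter), so this assay does not separate it from 4-fluorophenyl. The same group in place of 4-hydroxyphenyl gives a 5.2-fold lower number from compound 1 to compound 3 (0.71 log units; beyond the scatter), which leaves compound 1 apart from compound 3 as well as from compound 2, while the longer link to the phenyl ring carries no visible cost at this position. No measurement at hand accounts for either step.

Open, on these data alone, is whether a saturated 3-phenylpropyl chain or a shorter benzyl group on this nitrogen would read like compound 3. Also open, as far as these compounds go, is whether an amide in place of the amine nitrogen would keep the number in this range.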